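Swapping one halogenated ring for another at the limit

The compounds below may be only part of what the source reports. "The series", "measured", "known", "first", "only" and "open" are said of these compounds alone.

Compound 1 `C=CC1=C(C(=O)Nc2ccccc2OC)C(c2ccc(F)cc2)OC1`: in a functional assay on A549 cells (Homo sapiens) for cytotoxicity, read by MTT assay, with a stated time of 24 h (a higher number here means a weaker inhibitor, a lower number a stronger inhibitor), compound 1 gives > 100000 nM, a limit of the assay.
Compound 2 `C=CC1=C(C(=O)Nc2ccccc2)C(c2ccc(Cl)c(Cl)c2)OC1`: in this assay compound 2 gives > 100000 nM, also a limit of the assay.

Compound 2 thus stands at the limit of > 100000 nM in this assay, at which 2 of the 2 values shown sit, with no number below it. Compound 3 `C=CC1=C(C(=O)Nc2ccccc2)C(c2ccc(F)cc2)OC1` carries 4-fluorophenyl in place of 3,4-dichlorophenyl on a saturated ring carbon. Going by the values given here, no step between measured compounds is available, so the expectation rests on both values sitting at the limit: no change beyond the scatter is expected, and compound 3 is expected to remain at the limit, a step that the limit leaves unreadable from compound 2 to compound 3. The estimate for compound 3 is 150000 nM, ranging from 60000 nM to 400000 nM.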

Compound 3, half-maximal inhibitory concentration: > 100000 nM
Compound 3: no number, only a limit; the forecaster's own chance of this, stated with the estimate: 85%; the middle value does not contradict the limit.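

In this assay, going by these compounds alone, compound 3 gives > 100000 nM, a limit of the assay, so no step from compound 1 or compound 2 to compound 3 can be read. The compounds shown leave open how strongly each one acts, because all of them share one limit: the limit of > 100000 nM in this assay, at which 3 of the 3 values shown sit.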